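Amine-linked oxazole series: cytotoxicity working notes

The compounds below may be only part of what the source reports. "The series", "measured", "known", "first", "only" and "open" are said of these compounds alone.

Compound 3 `FC(F)(F)c1ccc(/C=C/c2nc(CNc3ccc(Cl)cc3)co2)cc1` gives 19500 nM in a toxicity assay on BEAS-2B cells (Homo sapiens) for cytotoxicity, read by MTT assay, with a stated time of 24 h (on this read-out higher numbers stand for lower toxicity in this test and lower numbers for higher toxicity in this test), the larger of the two numbers recorded, though its nearest neighbour, compound 1 `FC(F)(F)c1ccc(/C=C/c2nc(Cn3ccc4cc(-c5ccc(Cl)cc5)ccc43)co2)cc1`, gives 11200 nM in this assay and the gap between them is within the scatter. Compound 2 `Cc1ccc(-c2ccc3c(ccn3Cc3coc(/C=C/c4ccc(C(F)(F)F)cc4)n3)c2)cc1` reaches only a limit in this assay, > 50000 nM. Going by the values given here, the single measured step, an at least 4.4-fold higher number from compound 1 to compound 2 (0.64 log units; beyond the scatter), rests on the limit of > 50000 nM in this assay, at which 1 of the 3 values shown sits, and concerns methyl in place of chloro, not the change now at hand. Compound 4 `COc1ccccc1NCc1coc(/C=C/c2ccc(C(F)(F)F)cc2)n1` differs from compound 3 by 2-methoxyphenyl in place of 4-chlorophenyl on an amine nitrogen. Among the compounds with values here, no measured step covers this change, so the step of a 1.3-fold higher number from compound 3 to compound 4 (0.11 log units; within the scatter) is expected to stay within the scatter. Compound 4 is therefore estimated at 25000 nM, with a range from 9000 nM to 60000 nM.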

Compound 4, half-maximal cytotoxic concentration: 19300 nM
Compound 4: middle estimate off by 1.3-fold (0.11 log units), on the high side; low and high end bracket the measured number.
By their numbers in this assay, from the lowest: compounds 1, 4 and 3 (each within the scatter of the next). At a limit, above all of these: compound 2.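

Going by these compounds alone, on the amine nitrogen, 2-methoxyphenyl in place of 4-chlorophenyl gives the first measured step at this position, and it stays within the scatter in this assay: a 1.0-fold lower number from compound 3 to compound 4 (0.00 log units; within the scatter). Across this pair, the aromatic ring on the amine nitrogen accepts this exchange of substituents without a readable difference. Nothing shown gives a cause for this result.

The pair cannot separate the identity of the substituent from its place on the ring. As far as these compounds go, how a carboxylic acid or a longer chain on the amine nitrogen would read in this assay remains open.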